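Hydrazone aryl group changes on the diaryl ether urea series

The source may hold more compounds than are shown below. What is called first, only, known or untested is meant among the compounds shown, and "the series" means these compounds.

Measured so far in a functional assay on A549 cells (Homo sapiens) for cytotoxicity, read by MTT assay, with a stated time of 72 h; on this read-out lower numbers stand for stronger inhibition and higher numbers for weaker inhibition:
Compound 1 `COc1ccc(OC)c(/C=N/NC(=O)Nc2ccc(Oc3ccnc(-c4nncn4CCN(C)C)c3)c(F)c2)c1` gives 1950 nM.
Compound 2 `COc1ccc(/C=N/NC(=O)Nc2ccc(Oc3ccnc(-c4nncn4CCN(C)C)c3)c(F)c2)c(OC)c1OC` gives 6680 nM.
Compound 3 `CN(C)CCn1cnnc1-c1cc(Oc2ccc(NC(=O)N/N=C/c3ccc(O)c(O)c3)cc2F)ccn1` gives > 100000 nM, which is a limit of the assay rather than a number.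

Compound 2 holds the highest of the two numbers; its nearest neighbour is compound 1, with a 3.4-fold higher number from compound 1 to compound 2 (0.53 log units; beyond the scatter). The next step is 3-fluoro-4-hydroxyphenyl in place of 2,3,4-trimethoxyphenyl on a carbon with a double bond to nitrogen, giving compound 4 `CN(C)CCn1cnnc1-c1cc(Oc2ccc(NC(=O)N/N=C/c3ccc(O)c(F)c3)cc2F)ccn1`. Bearing on it are an at least 14-fold higher number from compound 2 to compound 3 (1.17 log units; beyond the scatter) and an at least 51-fold higher number from compound 1 to compound 3 (1.70 log units; beyond the scatter), both reaching (the limit of > 100000 nM in this assay, at which 1 of the 3 values shown sits), showing that hydroxyl groups on this ring cost activity strongly. Compound 4 carries one hydroxyl with a fluorine, so a sizeable loss is expected, a 3.7-fold higher number from compound 2 to compound 4 (0.57 log units; beyond the scatter). Compound 4 is therefore estimated at 25000 nM, within 6000 nM to 100000 nM.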

Compound 4, half-maximal inhibitory concentration: 13400 nM
Beside the measured number, compound 4's estimate is 1.9-fold (0.27 log units) above it; low and high end bracket the measured number.
By their numbers in this assay, from the lowest: compound 1; then compounds 2 and 4 (each within the scatter of the next). At a limit, above all of these: compound 3.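

Fluoro in place of hydroxy on an aromatic carbon gives an at least 7.4-fold lower number from compound 3 to compound 4 (0.87 log units; beyond the scatter), so a hydroxyl on this ring does not by itself abolish activity. Going by these compounds, compound 3 stands at a limit, > 100000 nM, so the true size of that step stays unknown. The 3-fluoro-4-hydroxyphenyl group cannot be told apart from 2,3,4-trimethoxyphenyl, with a 2.0-fold higher number from compound 2 to compound 4 (0.30 log units; within the scatter), while replacing 2,5-dimethoxyphenyl gives a 6.9-fold higher number from compound 1 to compound 4 (0.84 log units; beyond the scatter).

Open, on these data alone, is how a ring carrying an amine or a carboxylic acid in place of the hydroxyl would read. Also open, as far as these compounds go, is whether fluorine alone on this ring, without a hydroxyl, would read nearer compound 1.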